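Methyl on the anilide ring of the shared core

The compounds below may be only part of what the source reports. "The series", "measured", "known", "first", "only" and "open" are said of these compounds alone.

Compound 2, `O=C(/C=C/C(=O)N1C/C(=C\c2ccc([N+](=O)[O-])cc2)C(=O)/C(=C/c2ccc([N+](=O)[O-])cc2)C1)Nc1ccccc1`, gives 370 nM in a functional assay on CCRF-CEM cells (Homo sapiens) for cytotoxicity; a lower number here means a stronger inhibitor, a higher number a weaker inhibitor. Among the compounds with values here, it holds the lower of the two numbers measured so far, but the gap to compound 1, `Cc1ccc(NC(=O)/C=C/C(=O)N2C/C(=C\c3ccc([N+](=O)[O-])cc3)C(=O)/C(=C/c3ccc([N+](=O)[O-])cc3)C2)cc1C`, which gives 700 nM in this assay, lies within the scatter. Within the data shown here, the only measured step, a 1.9-fold lower number from compound 1 to compound 2 (0.28 log units; within the scatter), alters the same aryl group on the amide nitrogen and is itself within the scatter.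

Compound 3, `Cc1ccc(NC(=O)/C=C/C(=O)N2C/C(=C\c3ccc([N+](=O)[O-])cc3)C(=O)/C(=C/c3ccc([N+](=O)[O-])cc3)C2)cc1`, differs from compound 2 by methyl in place of hydrogen on an aromatic carbon; the methyl sits para to a large group, so compound 3 stands between compound 2 and compound 1 in how that ring is substituted. Because removing both methyls gave only a 1.9-fold lower number from compound 1 to compound 2 (0.28 log units; within the scatter), putting one methyl back is expected to move the number by no more than the scatter, if anything toward the value of compound 1. The estimate for compound 3 is therefore 450 nM, with a range of 230 nM to 900 nM. The expected step is a 1.2-fold higher number from compound 2 to compound 3 (0.09 log units; within the scatter).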

Compound 3, half-maximal inhibitory concentration: 890 nM
The estimate for compound 3 lay 2.0-fold (0.30 log units) below the measured number, within the range that was stated.
By their numbers in this assay, from the lowest: compounds 2, 1 and 3 (each within the scatter of the next, the first and the last beyond it).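

Phenyl to 4-methylphenyl on the anilide, with the methyl para to a large group, gives a 2.4-fold higher number from compound 2 to compound 3 (0.38 log units; beyond the scatter) in this assay and is the only step among the three compounds that clears the scatter. The further methyl of the 3,4-dimethylphenyl group cannot be read: a 1.3-fold higher number from compound 1 to compound 3 (0.10 log units; within the scatter) separates compound 1 and compound 3 by no more than the scatter, and the step from compound 1 to compound 2 also stays within it, so a single methyl stands clear of the unsubstituted phenyl while the two methyls do not. Nothing at hand bears on why a methyl at this place moves the number.

Still open, from the compounds shown here alone, is whether the step belongs to methyl itself or to any group at this place, which ethyl, methoxy or chlorine on the same carbon of the anilide ring would test on the shared core. Also open, going by these compounds, is what a ring bearing only the other methyl of compound 1 would give, and so whether the two methyls of compound 1 act independently of each other in this cell read-out.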